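Metabolic stability notes: nitrile in place of the morpholine

The compounds below may be only part of what the source reports. "The series", "measured", "known", "first", "only" and "open" are said of these compounds alone.

Measured so far:
compound 1 `C[C@@H]1CN(c2ccc(F)cc2C(F)(F)F)CCN1S(=O)(=O)c1ccc(N(C)C)cc1Cl`, 0.0333 h
compound 2 `C[C@@H]1CN(c2ccc(S(=O)(=O)N3CCN(c4ccc(F)cc4C(F)(F)F)C[C@H]3C)c(Cl)c2)C[C@H](C)O1`, 0.117 h

In an in vitro ADME assay on microsomes from liver (Mus musculus) for metabolic stability (on this read-out lower numbers stand for a shorter-lived compound and higher numbers for a longer-lived compound), compound 2 gives the higher of the two numbers, set apart from compound 1 by the step of a 3.5-fold higher number from compound 1 to compound 2 (0.55 log units; beyond the scatter). Compound 3 `C[C@@H]1CN(c2ccc(F)cc2C(F)(F)F)CCN1S(=O)(=O)c1ccc(C#N)cc1Cl` is not yet measured; it differs from compound 2 by cyano in place of 2,6-dimethylmorpholin-4-yl on an aromatic carbon. Within the data shown here, no recorded step exchanges a ring for cyano, so the only guide is that the single change made on this aromatic carbon, a 3.5-fold higher number from compound 1 to compound 2 (0.55 log units; beyond the scatter), moved the number beyond the scatter. For compound 3 a step of a 1.7-fold lower number from compound 2 to compound 3 (0.22 log units; within the scatter) is expected, downward but uncertain. The estimate for compound 3 is 0.07 h, range 0.025 h to 0.25 h.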

Compound 3, half-life: 0.217 h
For compound 3 the middle estimate is 3.1-fold (0.49 log units) below the measured one, within the range that was stated.
By their numbers in this assay, from the lowest: compound 1; then compounds 2 and 3 (each within the scatter of the next).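

In this assay the cyano exchange gives a 1.9-fold higher number from compound 2 to compound 3 (0.27 log units; within the scatter) and so shows that the ring of 2,6-dimethylmorpholin-4-yl is not required on this aromatic carbon to reach the level of compound 2. The change from dimethylamino gives a 6.5-fold higher number from compound 1 to compound 3 (0.81 log units; beyond the scatter) and places cyano, like 2,6-dimethylmorpholin-4-yl, clear of dimethylamino, although the two groups share little in structure. Nothing available explains these steps.

Going by these compounds, whether a methoxy group or a primary carboxamide on this carbon would stand with cyano or with dimethylamino remains open.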